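The source may hold more compounds than are shown below. What is called first, only, known or untested is meant among the compounds shown, and "the series" means these compounds.

Among the compounds with values here, in an in vivo ADME assay on the whole organism (plasma, strain Sprague-Dawley) for pharmacokinetics, with Rattus norvegicus as the target (a higher number here means faster removal of the compound, a lower number slower removal), three compounds have numbers so far. Compound 2 `O=C1[C@@H](NS(=O)(=O)c2ccc3c(Cl)c[nH]c3c2)CCN1c1ccc2c(c1)CCNC2` gives 7.7 mL/min/kg and lies within the scatter of compound 3 `O=C1[C@@H](NS(=O)(=O)c2ccc3cc[nH]c3c2)CCN1c1ccc2c(c1)CCNC2` at 12 mL/min/kg on this scale, while compound 1 `CN1CCc2cc(N3CC[C@H](NS(=O)(=O)/C=C/c4ccc(Cl)s4)C3=O)ccc2C1` at 26 mL/min/kg stands higher than compound 2, beyond the scatter.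

Compound 4 `O=C1[C@@H](NS(=O)(=O)c2ccc3c(Cl)c[nH]c3c2)CCN1c1ccc2c(c1F)CCNC2` differs from compound 2 in one place, by fluoro in place of hydrogen on an aromatic carbon and in plain words it carries fluoro in place of hydrogen on an aromatic carbon. Within the data shown here, only one measured step links two close relatives, a 1.6-fold higher number from compound 2 to compound 3 (0.19 log units; within the scatter) with hydrogen in place of chloro on an aromatic carbon elsewhere in the molecule. That step stayed within the scatter. Among the measured compounds shown here, it is a single example at another place, and no measured compound here carries fluoro, so it offers only weak guidance.

On this evidence, no step beyond the scatter is expected in this assay for the new fluoro group. The estimated step is a 1.0-fold lower number from compound 2 to compound 4 (0.01 log units; within the scatter) and it amounts to little change. For compound 4 the expected clearance is 7.5 mL/min/kg with an estimated range from 3.8 mL/min/kg to 15 mL/min/kg.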

Compound 4, clearance: 2.7 mL/min/kg
Estimate against measurement, compound 4: 2.8-fold (0.44 log units) above; measured number outside the range, below it.
By their numbers in this assay, from the lowest: compound 4; then compounds 2 and 3 (each within the scatter of the next); then compound 1.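

Placing fluoro on this aromatic carbon, ortho to a fused ring and ortho to a large group, gives a 2.9-fold lower number from compound 2 to compound 4 (0.46 log units; beyond the scatter) in this assay. Within the data shown here, this is the first step between close relatives here that lies beyond the scatter, whereas the only earlier one, hydrogen in place of chloro at another place in the molecule, gave a 1.6-fold higher number from compound 2 to compound 3 (0.19 log units; within the scatter) and stayed within it, so a change of just 1 heavy atom at this position can move the number measurably. Nothing measured here says why the number moves at this position.

A methyl or a methoxy group on this same carbon would help show whether the shift belongs to fluoro in particular or appears with other small groups at this position too. From the compounds shown here alone, it also remains open whether fluoro gives a similar step at the other aromatic carbons of this ring, or at this carbon in compound 3, which lacks the chloro, and a single pair cannot settle how general the step is.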